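The compounds below may be only part of what the source reports. "The series", "measured", "known", "first", "only" and "open" are said of these compounds alone.

Of the compounds shown here, three built on one shared core have been measured in a functional assay on LNCaP cells (Homo sapiens) for antiproliferative activity; a higher number here means a weaker inhibitor, a lower number a stronger inhibitor. Compound 1 `Cn1ncc(Cl)c1-c1cc(C(=O)N[C@@H]2CN[C@H](CC(=O)O)C[C@H]2c2ccc(Cl)c(Cl)c2)oc1Cl` gives 640 nM. Compound 2 `Cn1ncc(Cl)c1-c1cc(C(=O)N[C@@H]2CN[C@H](CCN3CCC(O)CC3)C[C@H]2c2ccc(Cl)c(Cl)c2)oc1Cl`, with (4-hydroxypiperidin-1-yl)methyl in place of carboxy on a saturated chain carbon bound to a saturated ring carbon, gives 1140 nM; the step of a 1.8-fold higher number from compound 1 to compound 2 (0.25 log units; within the scatter) stays within the scatter. Compound 3 `CNC(=O)C[C@@H]1C[C@@H](c2ccc(Cl)c(Cl)c2)[C@H](NC(=O)c2cc(-c3c(Cl)cnn3C)c(Cl)o2)CN1` gives 40 nM, the lowest of the three numbers, reached through a 16-fold lower number from compound 1 to compound 3 (1.20 log units; beyond the scatter) and a 29-fold lower number from compound 2 to compound 3 (1.45 log units; beyond the scatter).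

Compound 4 `CN(C)CC[C@@H]1C[C@@H](c2ccc(Cl)c(Cl)c2)[C@H](NC(=O)c2cc(-c3c(Cl)cnn3C)c(Cl)o2)CN1` is not yet measured. Its difference from compound 3: (dimethylamino)methyl in place of methylcarbamoyl on a saturated chain carbon bound to a saturated ring carbon. Going by the values given here, both large steps so far end at compound 3, where methylcarbamoyl enters and the number falls sharply, while compound 2, whose chain ends in a nitrogen-bearing group instead, sits highest. Taking methylcarbamoyl away again is therefore expected to raise the number, likely by part of the way back toward compound 2, giving an expected step of a 10-fold higher number from compound 3 to compound 4 (1.00 log units; beyond the scatter). Compound 4 is estimated at 400 nM, within a range of 120 nM to 1400 nM.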

Compound 4, half-maximal inhibitory concentration: 1930 nM
The estimate for compound 4 lay 4.8-fold (0.68 log units) below the measured number; the measured number lies above the stated range.
By their numbers in this assay, from the lowest: compound 3; then compounds 1, 2 and 4 (each within the scatter of the next, the first and the last beyond it).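

In this assay, the step of a 48-fold higher number from compound 3 to compound 4 (1.68 log units; beyond the scatter) shows that this position tells two groups apart even though both have 4 heavy atoms and no ring: methylcarbamoyl brings a carbonyl and a hydrogen-bond donor, and (dimethylamino)methyl brings neither. The step of a 1.7-fold higher number from compound 2 to compound 4 (0.23 log units; within the scatter) stays within the scatter, so dimethylamino and 4-hydroxypiperidin-1-yl cannot be separated here, and the low number of compound 3 is not matched by either of these amine chains. The step of a 3.0-fold higher number from compound 1 to compound 4 (0.48 log units; beyond the scatter) lies beyond the scatter but is modest, which leaves the carboxy compound and the dimethylamino compound far closer to each other than either is to compound 3.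

From the compounds shown here alone, whether the carbonyl or the amide hydrogen matters more stays open, and a dimethylcarbamoyl group, which keeps the carbonyl without that hydrogen, would address it. Nothing shown gives a measured reason for these gaps.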